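Urea aryl change in a cytotoxicity series

The source may report more compounds than this note shows. Statements on the series, on what has been measured and on what is new or still open speak of the compounds shown alone.

Measured compounds:
compound 1, `CN(C)CCCNc1nc(-c2ccc(NC(=O)Nc3ccc(F)cc3)cc2)nc2c(Cl)c(Cl)sc12`: 980 nM
compound 2, `CN(C)CCCNc1nc(-c2ccc(NC(=O)Nc3ccc(Cl)cc3Cl)cc2)nc2ccsc12`: 1860 nM

Among the compounds with values here, in a functional assay on MDA-MB-231 cells (Homo sapiens) for cytotoxicity, read by MTT assay, with a stated time of 72 h (a higher number here means a weaker inhibitor, a lower number a stronger inhibitor), compound 1 gives 980 nM, the lowest of the two numbers so far. Compound 2 gives 1860 nM in this assay; the two values lie within the usual scatter of each other, so nothing can be said about an order between them. Compound 2 also differs from compound 1 in more than one place, so no single change is isolated by the pair.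

Compound 3, `CN(C)CCCNc1nc(-c2ccc(NC(=O)Nc3ccccc3Cl)cc2)nc2c(Cl)c(Cl)sc12`, differs from compound 1 in one place: 2-chlorophenyl in place of 4-fluorophenyl on an amide-type nitrogen. Within the data shown here, no measured pair shows this change on its own, and the two numbers available give no direction for it. The working expectation is a step from compound 1 to compound 3 that does not exceed the scatter, and the estimated step is a 1.2-fold higher number from compound 1 to compound 3 (0.09 log units; within the scatter).

Compound 3 is therefore expected to give about 1200 nM in this assay, with an estimated range from 500 nM to 3000 nM.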

Compound 3, half-maximal inhibitory concentration: 1560 nM
The estimate for compound 3 lay 1.3-fold (0.11 log units) below the measured number; measured number inside the range.
By their numbers in this assay, from the lowest: compounds 1, 3 and 2 (each within the scatter of the next).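

In this assay, within the data shown here, compound 1 and compound 3 form the first pair that differs in one place, and 2-chlorophenyl in place of 4-fluorophenyl on an amide-type nitrogen gives a 1.6-fold higher number from compound 1 to compound 3 (0.20 log units; within the scatter). With the rest of the molecule held constant, this exchange of one halogen-bearing phenyl group for another therefore leaves compound 1 and compound 3 indistinguishable in this read-out, which the earlier pair, differing in more than one place, could not show. No measurement available here explains this result.

The change replaces fluorine with chlorine and also moves the substituent, so the two contributions remain unseparated; 4-chlorophenyl and 2-fluorophenyl on the same nitrogen would separate them. Going by these compounds, it also remains open whether a different kind of group at this position, such as a pyridyl ring, a phenyl ring carrying a methoxy group or a carboxylic acid, or a longer chain, would shift the number beyond the scatter.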